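The source may report more compounds than this note shows. Statements on the series, on what has been measured and on what is new or still open speak of the compounds shown alone.

Compound 2 `COc1ccccc1-c1cn(C[C@H](O)[C@H]2OC(=O)C(OCc3ccccc3)=C2OCc2ccccc2)nn1` carries a 2-methoxyphenyl group on the shared core. In a functional assay on SW-620 cells (Homo sapiens) for antiproliferative activity, read by MTT assay, with a stated time of 72 h (on this read-out higher numbers stand for weaker inhibition and lower numbers for stronger inhibition), compound 2 gives only a limit of the assay, > 100000 nM. Compound 1 `O=C1O[C@H]([C@@H](O)Cn2cc(-c3ccc(Br)cc3)nn2)C(OCc2ccccc2)=C1OCc1ccccc1`, which carries 4-bromophenyl at the same place, gives 3760 nM in this assay, and the change to the 2-methoxyphenyl group was an at least 26-fold higher number from compound 1 to compound 2 (1.42 log units; beyond the scatter), which sets compound 2 on (the limit of > 100000 nM in this assay, at which 1 of the 2 values shown sits). Compound 3 `O=C1O[C@H]([C@@H](O)Cn2cc(CNS(=O)(=O)c3ccc(F)cc3)nn2)C(OCc2ccccc2)=C1OCc1ccccc1` differs from compound 2 by (((4-fluorophenyl)sulfonyl)amino)methyl in place of 2-methoxyphenyl on an aromatic carbon. Among the measured compounds shown here, only that one measured step bears on this new change, and it shows that the group on this carbon can move the result by a large step. A sulfonamide-bearing chain has not been measured here, so the outcome is open. The expected step is an at least 5.0-fold lower number from compound 2 to compound 3 (0.69 log units; beyond the scatter), toward a measurable number rather than a limit. Compound 3 is estimated at 20000 nM, between 3000 nM and 100000 nM.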

Compound 3, half-maximal inhibitory concentration: 41100 nM
The estimate for compound 3 lay 2.1-fold (0.31 log units) below the measured number, and the stated range covers the measured number.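

Placing (((4-fluorophenyl)sulfonyl)amino)methyl on this carbon instead of 2-methoxyphenyl gave an at least 2.4-fold lower number from compound 2 to compound 3 (0.38 log units; beyond the scatter), so in this assay a group other than a simple substituted phenyl can still give a measurable number here. That step can be read only as a minimum, because compound 2 gives only a limit of the assay: the limit of > 100000 nM in this assay, at which 1 of the 3 values shown sits. The same chain in place of 4-bromophenyl gave an 11-fold higher number from compound 1 to compound 3 (1.04 log units; beyond the scatter), so compound 1 remains the strongest of the three.

Going by these compounds, whether the sulfonyl part of the chain or its fluorophenyl ring matters in compound 3 remains open, and a plain aminomethyl group on this carbon would help to separate them. Also open, on these data alone, is whether the bromine or its ring position sets compound 1 apart, a question that 4-methoxyphenyl and 2-bromophenyl groups could address.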